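Pentafluoroethyl in place of cyano: expected step

This account rests on a few compounds, and the source may have more. Where it says the series, first, only, none or still open, it means among the compounds named here.

Values in a functional assay (aorta) with Rattus norvegicus as the target; on this read-out lower numbers stand for an effect already at smaller amounts and higher numbers for an effect only at larger amounts of compound
- compound 1 (`O=C1CCCCN1C1=CC(CF)(CF)Oc2ccc(C(F)(F)C(F)(F)F)cc21`): 5.62 nM
- compound 2 (`N#Cc1ccc2c(c1)C(n1ccccc1=O)=CC(CF)(CF)O2`): 24.6 nM

Of these two numbers, compound 2 has the higher at 24.6 nM and lies beyond the scatter from compound 1. Compound 3 (`O=c1ccccn1C1=CC(CF)(CF)Oc2ccc(C(F)(F)C(F)(F)F)cc21`) has not yet been measured. In it, 1,1,2,2,2-pentafluoroethyl stands in place of cyano on an aromatic carbon (1,1,2,2,2-pentafluoroethyl in place of cyano on an aromatic carbon). Among the compounds with values here, no measured pair differs in one place only, so the size of this change has not been observed directly. The expectation rests on compound 1, which also carries 1,1,2,2,2-pentafluoroethyl and gives 5.62 nM in this assay on a core that is not the same. The expected step of a 4.9-fold lower number from compound 2 to compound 3 (0.69 log units; beyond the scatter) is towards a lower number and is estimated to lie beyond the scatter. For compound 3 the estimated value is 5 nM with an expected range from 1.5 nM to 17 nM as a working figure.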

Compound 3, half-maximal effective concentration: 2.95 nM
Compound 3: middle estimate off by 1.7-fold (0.23 log units), on the high side; low and high end bracket the measured number.
By their numbers in this assay, from the lowest: compounds 3 and 1 (each within the scatter of the next); then compound 2.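

In this assay, within the data shown here, 1,1,2,2,2-pentafluoroethyl in place of cyano on an aromatic carbon gives an 8.3-fold lower number from compound 2 to compound 3 (0.92 log units; beyond the scatter), the first direct reading of this change at this place on the shared core. With 1,1,2,2,2-pentafluoroethyl held constant, replacing the six-membered non-aromatic ring group on the double-bonded ring carbon with the six-membered aromatic ring group gives a 1.9-fold lower number from compound 1 to compound 3 (0.28 log units; within the scatter), so this ring exchange is not resolved from the scatter. No supporting data on hand account for either step.

The compounds shown hold only one pair for the cyano exchange, so its size with the six-membered non-aromatic ring group on the double-bonded ring carbon stays open. Also open, as far as these compounds go, is how trifluoromethyl or an amine on the same aromatic carbon would read in this assay.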